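A few compounds are considered here, and "the series" means these few. Any claim that something is new, unique, unknown or untested is made for them only; others in the source may bear on it.

Three compounds share one core and are compared in an assay on CHO cells for displacement of a labelled ligand from Melanocortin receptor 4 (Homo sapiens); a lower number here means a stronger inhibitor, a higher number a weaker inhibitor. Compound 1 `CC[C@H](NC(C)=O)c1cc(Cl)ccc1C1CCN(C(=O)[C@@H]2CN(C(C)(C)C)C[C@H]2c2ccc(F)cc2F)CC1` gives 70 nM. For the measured compounds named here, compound 2 `CC[C@H](NC(C)=O)c1cc(Cl)ccc1C1CCN(C(=O)[C@@H]2CN(C(C)(C)C)C[C@H]2c2ccc(Cl)cc2Cl)CC1` gives 17.9 nM; the step of a 3.9-fold lower number from compound 1 to compound 2 (0.59 log units; beyond the scatter) is the only change between measured compounds that alters a single place. Compound 3 `CC[C@H](NC(C)=O)c1cc(Cl)ccc1C1CCN(C(=O)[C@H]2CN(C(C)(C)C)C[C@@H]2c2ccc(F)cc2Cl)CC1` gives 82.2 nM, the highest of the three numbers; compared with compound 1 its number lies within the scatter, and compared with compound 2 it lies beyond it.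

Compound 4 `CC[C@H](NC(C)=O)c1cc(Cl)ccc1C1CCN(C(=O)[C@@H]2CN(C(C)(C)C)C[C@H]2c2ccc(F)cc2Cl)CC1` has not yet been measured. Its difference from compound 3 is the two compounds have the same atoms and bonds and differ only in configuration as drawn: 2 of 3 stereo elements differ; a stereocentre at a saturated ring carbon is drawn R in compound 3 and S in compound 4; a stereocentre at a saturated ring carbon is drawn S in compound 3 and R in compound 4. Compound 4 thus carries the same configuration at those two ring carbons as compound 1 and compound 2, while its aryl group, with one chlorine and one fluorine, sits between the two aryl groups of those compounds. Going by the values given here, no measured step changes configuration alone, so the size of this step is uncertain. The step of a 3.9-fold lower number from compound 1 to compound 2 (0.59 log units; beyond the scatter) suggests that with this configuration the mixed aryl group would fall between compound 1 and compound 2.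

Compound 4 is therefore expected to show the step of a 2.3-fold lower number from compound 3 to compound 4 (0.37 log units; beyond the scatter), a lower number. The estimate for compound 4 is 35 nM, within a range from 12 nM to 100 nM.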

Compound 4, half-maximal inhibitory concentration: 216 nM
Compound 4: the middle estimate sits 6.2-fold (0.79 log units) below what was measured, outside the stated range (above it).
By their numbers in this assay, from the lowest: compound 2; then compounds 1 and 3 (each within the scatter of the next); then compound 4.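

In this assay, compound 3 and compound 4 show a 2.6-fold higher number from compound 3 to compound 4 (0.42 log units; beyond the scatter), and this shift can come from one source only: the fact that compounds 3 and 4 differ only in the configuration as drawn Among the compounds sharing the configuration of compound 4, the aryl group does not follow a smooth scale from two fluorines to two chlorines, as the earlier step alone might have suggested: with chloro in place of fluoro on an aromatic carbon there is a 3.1-fold higher number from compound 1 to compound 4 (0.49 log units; beyond the scatter), and with fluoro in place of chloro on an aromatic carbon there is a 12-fold higher number from compound 2 to compound 4 (1.08 log units; beyond the scatter). Each single halogen swap into the mixed group thus raises the number, so one chlorine with one fluorine gives the weakest binder of these four, and the effect of one halogen cannot be read without knowing the other.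

From the compounds shown here alone, only the mixed aryl group appears here in both configurations, and it remains open whether the configuration of compound 3 would also give the lower number with the dichlorophenyl or difluorophenyl group. Also open, going by these compounds, is how a bromine or a methoxy group on the aromatic ring would fit this uneven halogen pattern.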